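From Chloro to Bromo: One Halogen Step Further

A few compounds are considered here, and "the series" means these few. Any claim that something is new, unique, unknown or untested is made for them only; others in the source may bear on it.

The series rests on a shared core with one aromatic ring whose single substituent is varied. Compound 1 `O/N=C(/Nc1ccccc1)c1ccc2occc2c1` carries hydrogen at that place, and in an assay on tissue (HeLa cells) for inhibition of Indoleamine 2,3-dioxygenase 1 (Homo sapiens), read by spectrophotometry (on this read-out lower numbers stand for stronger inhibition and higher numbers for weaker inhibition), compound 1 gives 19000 nM. Compound 2 `O/N=C(/Nc1cccc(F)c1)c1ccc2occc2c1` carries fluoro there, and in this assay compound 2 gives 20000 nM; the step of a 1.1-fold higher number from compound 1 to compound 2 (0.02 log units; within the scatter) is within the scatter. Compound 3 `O/N=C(/Nc1cccc(Cl)c1)c1ccc2occc2c1` carries chloro, and in this assay compound 3 gives 1500 nM. This is the lowest of the three numbers: the step of a 13-fold lower number from compound 1 to compound 3 (1.10 log units; beyond the scatter) and the step of a 13-fold lower number from compound 2 to compound 3 (1.12 log units; beyond the scatter) are both large and beyond the scatter, so compound 3 stands clearly apart from the other two.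

Compound 4 `O/N=C(/Nc1cccc(Br)c1)c1ccc2occc2c1` continues the halogen series with bromo in place of chloro on an aromatic carbon. Among the measured compounds shown here, no measured step in this assay goes from chloro to bromo; the steps that bear on it are the two large ones into compound 3 from hydrogen and from fluoro, while hydrogen to fluoro stayed within the scatter. A further gain of comparable size is not expected, but a modest step in the same direction is plausible, giving an expected 1.5-fold lower number from compound 3 to compound 4 (0.18 log units; within the scatter). For compound 4 in this assay the estimate is 1000 nM, expected between 300 nM and 4000 nM.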

Compound 4, half-maximal inhibitory concentration: 1100 nM
Beside the measured number, compound 4's estimate is 1.1-fold (0.04 log units) below it; measured number inside the range.
By their numbers in this assay, from the lowest: compounds 4 and 3 (each within the scatter of the next); then compounds 1 and 2 (each within the scatter of the next).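

In this assay the step of a 1.4-fold lower number from compound 3 to compound 4 (0.13 log units; within the scatter) stays within the scatter, so on this aromatic carbon, meta to a large group, bromo and chloro cannot be told apart and the result seen with chloro is not unique to that halogen. Set against hydrogen, bromo gives a 17-fold lower number from compound 1 to compound 4 (1.24 log units; beyond the scatter) and set against fluoro it gives an 18-fold lower number from compound 2 to compound 4 (1.26 log units; beyond the scatter) and both steps are large, so the four compounds fall into two levels, with hydrogen and fluoro on one and chloro and bromo on the other, and none of the four goes against that split. Nothing measured here explains why the halogens divide in this way.

The compounds shown leave open whether iodo would join chloro and bromo at this place, and whether a group that is not a halogen, such as methyl, methoxy or trifluoromethyl, would reach the same level. They also leave open whether the split between the halogens would hold at another place on this ring or on a changed version of the shared core.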